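The compounds below may be only part of what the source reports. "The series", "measured", "known", "first", "only" and "open" are said of these compounds alone.

Measured so far in an assay on HEK293 cells for agonist activity at transient receptor potential cation channel subfamily M member 8 (Homo sapiens), read by fluorescence and calcium flux, with a stated time of 15 min; on this read-out higher numbers stand for an effect only at larger amounts of compound and lower numbers for an effect already at smaller amounts:
- compound 1 `Cc1ccc(OCC(=O)N(Cc2cccs2)c2nccs2)cc1`: 2240 nM
- compound 2 `C=CCN(Cc1cccs1)C(=O)COc1ccc(C)cc1`: 20 nM

Compound 2 stands lowest of the two numbers; the nearest, compound 1, sits at a 110-fold lower number from compound 1 to compound 2 (2.05 log units; beyond the scatter) away, a step that swaps the group on the amide-type nitrogen. Compound 3 `Cc1ccc(OCC(=O)N(CCO)Cc2cccs2)cc1` differs from compound 2 by hydroxymethyl in place of vinyl on a saturated chain carbon bound to an amide-type nitrogen. Going by the values given here, no measured step touches this position directly; the only step known, from compound 1 to compound 2, shows that the nitrogen substituent moves the read-out strongly, but gives no direction for this smaller swap. A moderate rise in the number is expected for compound 3, about a 7.5-fold higher number from compound 2 to compound 3 (0.88 log units; beyond the scatter), giving an estimate of 150 nM with a range of 30 nM to 1000 nM.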

Compound 3, half-maximal effective concentration: 900 nM
For compound 3 the middle estimate is 6.0-fold (0.78 log units) below the measured one; the range from low to high includes it.
By their numbers in this assay, from the lowest: compound 2; then compound 3; then compound 1.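

In this assay the nitrogen substituent matters even for a swap of similar size: allyl to 2-hydroxyethyl on the amide-type nitrogen gives a 45-fold higher number from compound 2 to compound 3 (1.65 log units; beyond the scatter) on this position. Against 1,3-thiazol-2-yl, the 2-hydroxyethyl group gives only a 2.5-fold lower number from compound 1 to compound 3 (0.40 log units; beyond the scatter), so allyl remains well ahead of both groups. No evidence on the cause of these steps is available. The compounds shown leave open whether the loss follows from the missing double bond or from the added oxygen. A propyl or 2-methoxyethyl group on that nitrogen would separate the two.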